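This account rests on a few compounds, and the source may have more. Where it says the series, first, only, none or still open, it means among the compounds named here.

Among the compounds with values here, compound 1, `CC(C(=O)N1CCN(c2ccccc2F)CC1)N1C(=O)CCC1=O`, gives 50% in a functional assay on the whole organism (strain Swiss) with Mus musculus as the target, in the maximal electroshock model, with a stated time of 0.5 h, at a dose of 300 mg/kg by the intraperitoneal route (a higher number here means a stronger effect of the compound at the dose given, a lower number a weaker effect), the lowest of the two numbers measured so far. Compound 2, `CCC(C(=O)N1CCN(c2ccccc2F)CC1)N1C(=O)CCC1=O`, gives 100%, and the step of a number 50 percentage points higher from compound 1 to compound 2 (beyond the scatter) concerns a different part of the shared core. Compound 3, `CC(C(=O)N1CCN(c2ccccc2Cl)CC1)N1C(=O)CCC1=O`, differs from compound 1 by chloro in place of fluoro on an aromatic carbon. Within the data shown here, no measured step bears on this change, so the data give no ground to expect a step beyond the scatter in this assay. The step of no change at the digits printed from compound 1 to compound 3 (within the scatter) is therefore expected to lie within the scatter. Compound 3 is estimated at 50%, with a range from 25% to 75%.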

Compound 3, a percentage reported as activity, at one dose (the size of the read-out at that dose, not a potency): 0%
For compound 3 the middle estimate is 50 percentage points above the measured one; the measured number lies below the stated range.
By their numbers in this assay, from the lowest: compound 3; then compound 1; then compound 2.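

In this assay, the aromatic position also proves sensitive: chloro in place of fluoro, on an aromatic carbon ortho to a large group, gives a number 50 percentage points lower from compound 1 to compound 3 (beyond the scatter). Earlier, only the saturated chain carbon had shown a step, and that one, a number 50 percentage points higher from compound 1 to compound 2 (beyond the scatter), went upward, so the read-out of compound 1 can move either way depending on the place changed. No measurement at hand offers a reason for the drop.

Still open, from the compounds shown here alone, is how bromo, methoxy or plain hydrogen would fare at this aromatic carbon. Also open, going by these compounds, is whether chloro would give a similar drop on the longer chain of compound 2.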